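The compounds below may be only part of what the source reports. "The series", "measured", "known", "first", "only" and "open" are said of these compounds alone.

Measured so far:
Compound 1 `CCOC(=O)c1cc(-c2ccc(Oc3ccccc3)cc2)nn1Cc1cccc(NC(=O)CCl)c1` — 400 nM
Compound 2 `C/C=C/C(=O)Nc1cccc(Cn2nc(-c3ccc(Oc4ccccc4)cc3)cc2CO)c1` — 5700 nM
Compound 3 `C=CC(=O)Nc1cccc(Cn2nc(-c3ccc(Oc4ccccc4)cc3)cc2CO)c1` — 6000 nM

All three numbers come from a functional assay on Z-138 cells (Homo sapiens) for inhibition, read by luminescence and CellTiter-Glo, with a stated time of 72 h; on this read-out higher numbers stand for weaker inhibition and lower numbers for stronger inhibition. Compound 3 gives the highest of the three, but the step of a 1.1-fold higher number from compound 2 to compound 3 (0.02 log units; within the scatter) is within the scatter, so compounds 2 and 3 cannot be placed in order. Compound 1 gives 400 nM, whereas compound 3 gives 6000 nM; the two differ at the amide and also in the group on the shared core, so no single change accounts for that gap.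

Compound 4 `O=C(CCl)Nc1cccc(Cn2nc(-c3ccc(Oc4ccccc4)cc3)cc2CO)c1` differs from compound 3 by chloromethyl in place of vinyl on a carbonyl carbon. Going by the values given here, no measured step bears directly on this exchange: the only measured step, a 1.1-fold higher number from compound 2 to compound 3 (0.02 log units; within the scatter), concerns a different change at the same carbonyl carbon and stayed within the scatter. Among the compounds with values here, compound 1 is the only measured compound with chloromethyl on that carbon, and its lower number cannot be separated from its other difference. A lower number is therefore expected for compound 4 only tentatively, as a 2.4-fold lower number from compound 3 to compound 4 (0.38 log units; beyond the scatter), with wide uncertainty. Compound 4 is estimated at 2500 nM, within 600 nM to 9000 nM.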

Compound 4, half-maximal inhibitory concentration: 400 nM
Compound 4: the middle estimate sits 6.3-fold (0.80 log units) above what was measured, outside the stated range (below it).
By their numbers in this assay, from the lowest: compounds 1 and 4 (each within the scatter of the next); then compounds 2 and 3 (each within the scatter of the next).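

In this assay the group on the carbonyl carbon proves decisive: chloromethyl in place of vinyl gives a 15-fold lower number from compound 3 to compound 4 (1.18 log units; beyond the scatter) and chloromethyl in place of prop-1-en-1-yl gives a 14-fold lower number from compound 2 to compound 4 (1.15 log units; beyond the scatter), although the exchange between vinyl and prop-1-en-1-yl had shown no separable effect. Hydroxymethyl in place of ethoxycarbonyl on an aromatic carbon gives no change at the digits printed from compound 1 to compound 4 (within the scatter), so with chloromethyl on the carbonyl carbon this second difference has no effect that can be told from the scatter. Nothing at hand shows what lies behind the large step from vinyl to chloromethyl.

Going by these compounds, it remains open whether bromomethyl, a plain methyl or a longer chain on the carbonyl carbon would give numbers like those of chloromethyl. Also open, on these data alone, is whether an amine or a carboxylic acid on the aromatic carbon would leave the number as undisturbed as hydroxymethyl and ethoxycarbonyl do.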